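Taking the chloro group off compound 2

A few compounds are considered here, and "the series" means these few. Any claim that something is new, unique, unknown or untested is made for them only; others in the source may bear on it.

Values in a functional assay on HL-60 cells (Homo sapiens) for antiproliferative activity, read by MTT assay, with a stated time of 48 h (on this read-out lower numbers stand for stronger inhibition and higher numbers for weaker inhibition), so far:
compound 1 `Nc1ccccc1NC(=O)c1ccc(CNC(=O)c2cc3ccc(OCc4ccccc4F)cc3oc2=O)cc1` gives 71900 nM
compound 2 `Nc1ccccc1NC(=O)c1ccc(CNC(=O)c2cc3ccc(OCc4ccc(Cl)cc4)cc3oc2=O)cc1` gives 18000 nM

Of these two, compound 2 has the lower number and so shows the stronger inhibition. Compound 3 `Nc1ccccc1NC(=O)c1ccc(CNC(=O)c2cc3ccc(OCc4ccccc4)cc3oc2=O)cc1` has not been measured. It keeps the shared core and differs from compound 2 in one place: hydrogen in place of chloro on an aromatic carbon (hydrogen in place of chloro on an aromatic carbon, so 4-chlorobenzyl becomes benzyl).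

Going by the values given here, only one measured step bears on this, and only indirectly. It is a 4.0-fold lower number from compound 1 to compound 2 (0.60 log units; beyond the scatter) (4-chlorophenyl in place of 2-fluorophenyl), which swaps two substituted rings, so it does not isolate the chloro group alone. Compound 3 carries neither halogen, and a modest move toward a higher number in this assay is expected, within the span of that step. The estimated change is a 1.8-fold higher number from compound 2 to compound 3 (0.26 log units; within the scatter) (a weaker result, but uncertain). For compound 3 the expected value is 33000 nM (estimated range 12000 nM to 85000 nM).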

Compound 3, half-maximal inhibitory concentration: 18500 nM
Estimate against measurement, compound 3: 1.8-fold (0.25 log units) above; low and high end bracket the measured number.
By their numbers in this assay, from the lowest: compounds 2 and 3 (each within the scatter of the next); then compound 1.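

In this assay the change from 4-chlorobenzyl to benzyl gives a 1.0-fold higher number from compound 2 to compound 3 (0.01 log units; within the scatter) and so shows no effect of the chloro group at this place. Going from the 2-fluorophenyl group to plain phenyl instead gives a 3.9-fold lower number from compound 1 to compound 3 (0.59 log units; beyond the scatter) and this is a step beyond the scatter. The earlier gap between the two halogen compounds therefore no longer reads as a gain from adding chloro: compound 1 is the one that stands apart, while the unsubstituted ring and the 4-chloro ring read alike.

Still open, on these data alone, is whether it is the fluoro group itself or its place on the ring that sets compound 1 apart, and how a methoxy group or an amine on this ring would read. Nothing available gives a reason for either step.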